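The compounds below may be only part of what the source reports. "The series", "measured", "known", "first", "only" and "open" are said of these compounds alone.

Of the compounds shown here, three have so far been read in an ADME assay on HEp-2 cells (Homo sapiens) for cytotoxicity, read by MTT assay, with a stated time of 72 h; a higher number here means a weaker inhibitor, a lower number a stronger inhibitor. Compound 1 (`COc1ccc(C2=C(c3cc(OC)c(OC)c(OC)c3)C(=O)C(O[SiH2]C(C)(C)C)C2)cc1`) gives a measured number, 16 ug/mL. Compound 2 (`COc1ccc(C2=C(c3cc(OC)c(OC)c(OC)c3)C(=O)CC2O[SiH2]C(C)(C)C)cc1OC`) stands at > 100 ug/mL, which is a limit of the assay and not a number. Compound 3 (`CC(=O)OC1C/C(=N/O)C(c2ccccc2)=C1c1ccccc1`) gives > 100 ug/mL, which is likewise a limit.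

Compound 4 (`COc1ccc(C2=C(c3cc(OC)c(OC)c(OC)c3)C(=O)CC2O[SiH2]C(C)(C)C)cc1O`) departs from compound 2 by hydrogen in place of methyl on an oxygen on an aromatic ring, so that 3,4-dimethoxyphenyl becomes 3-hydroxy-4-methoxyphenyl. Among the compounds with values here, no measured pair shows this change, so any expectation is loose. Compound 1, at 16 ug/mL, shows only that a close relative can give a number in this assay. A moderate shift toward stronger inhibition is expected, with an at least 1.6-fold lower number from compound 2 to compound 4 (0.22 log units; that floor lies within the scatter) as the estimated step, though a reading that remains a limit is quite possible. Compound 4 is estimated at 60 ug/mL, with an expected range of 12 ug/mL to 150 ug/mL.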

Compound 4, half-maximal inhibitory concentration: 14.5 ug/mL
Estimate against measurement, compound 4: 4.1-fold (0.62 log units) above; the range from low to high includes it.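

In this assay, hydrogen in place of methyl on an oxygen on an aromatic ring, so that 3,4-dimethoxyphenyl becomes 3-hydroxy-4-methoxyphenyl, gives an at least 6.8-fold lower number from compound 2 to compound 4 (0.83 log units; beyond the scatter) and is the first step that can be read among these compounds. This one place on the ring therefore separates a compound that gives a measured number from one that does not. From the compounds shown here alone, the true size of the step stays unknown, and the printed figure is only a floor, because compound 2 stands at a limit of the assay and not at a number: the limit of > 100 ug/mL in this assay, at which 2 of the 4 values shown sit.

Going by these compounds, what an amine or a longer chain such as ethoxy would do at this oxygen-bearing place remains open. On these data alone, whether the same change would lower the number on the core of compound 1 is also open.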